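A thiophen-2-yl swap at the edge of the measurable range

The source may hold more compounds than are shown below. What is called first, only, known or untested is meant among the compounds shown, and "the series" means these compounds.

Of the compounds shown here, three sharing one core have been tested in a functional assay on SK-MEL-28 cells (Homo sapiens) for inhibition, read by MTT assay, with a stated time of 48 h; on this read-out lower numbers stand for stronger inhibition and higher numbers for weaker inhibition. Compound 1 `CCc1ccc(-c2nc3ccccn3c2Sc2ccccc2)cc1` gives > 100000 nM, which is a limit of the assay and not a number. Compound 2 `COc1ccc(-c2nc3ccccn3c2Sc2ccccc2)cc1` gives 83900 nM. Compound 3 `CSc1ccc(-c2nc3ccccn3c2Sc2ccccc2)cc1` gives 67700 nM, within the scatter of compound 2, so the two cannot be told apart.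

Compound 4 `c1ccc(Sc2c(-c3cccs3)nc3ccccn23)cc1` differs from compound 3 in one place, with thiophen-2-yl in place of 4-(methylsulfanyl)phenyl on an aromatic carbon.

The measured steps offer only indirect guidance, as none of them replaces this whole group. Within the data shown here, the one step between two real numbers, a 1.2-fold lower number from compound 2 to compound 3 (0.09 log units; within the scatter), is small. The other two, an at least 1.1-fold lower number from compound 1 to compound 2 (0.07 log units; that floor lies within the scatter) and an at least 1.4-fold lower number from compound 1 to compound 3 (0.16 log units; that floor lies within the scatter), start from a limit, so they give only a floor for their size. On this evidence, no step beyond the scatter is expected in this assay, and no direction can be favoured with confidence. A result at the limit, as seen for compound 1, also remains possible. The expected change is small, a 1.0-fold higher number from compound 3 to compound 4 (0.01 log units; within the scatter). For compound 4 the estimated value is 70000 nM, with an expected range of 30000 nM to 100000 nM.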

Compound 4, half-maximal inhibitory concentration: 85300 nM
Estimate against measurement, compound 4: 1.2-fold (0.09 log units) below, within the range that was stated.
By their numbers in this assay, from the lowest: compounds 3, 2 and 4 (each within the scatter of the next). At a limit, above all of these: compound 1.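

Until now, only the small group on the phenyl ring had changed. Compound 4 replaces the whole group, with 4-(methylsulfanyl)phenyl of 8 heavy atoms giving way to thiophen-2-yl of 5, yet in this assay the read-out stays within the scatter, as shown by a 1.3-fold higher number from compound 3 to compound 4 (0.10 log units; within the scatter) and by a 1.0-fold higher number from compound 2 to compound 4 (0.01 log units; within the scatter). On this read-out, then, a five-membered aromatic ring without any further group on it cannot be told apart from the two larger groups in compound 2 and compound 3. Compound 1 remains a limit of the assay and not a number, so an at least 1.1-fold lower number from compound 1 to compound 4 (0.06 log units; that floor lies within the scatter) gives only a floor for that step: the limit of > 100000 nM in this assay, at which 1 of the 4 values shown sits.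

Going by these compounds, it remains open whether an amine or a carboxylic acid on the phenyl ring, or a saturated ring such as cyclohexyl in place of the aromatic one, would move the number beyond the scatter. On these data alone, the phenylsulfanyl group is the same in all four compounds, so the effect of replacing it, for instance with a benzyl group, also remains open.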